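Aziridine carbonyl ureas: nitro to sulfamoyl step

The compounds below may be only part of what the source reports. "The series", "measured", "known", "first", "only" and "open" are said of these compounds alone.

Measured so far:
compound 1, `N#CC1CN1C(=O)Nc1ccc(Cl)c(Cl)c1`, 2700 nM
compound 2, `N#CC1CN1C(=O)Nc1ccc([N+](=O)[O-])cc1`, 8600 nM

Two compounds of the series have numbers in a functional assay on RPMI-8226 cells (Homo sapiens) for inhibition; a lower number here means a stronger inhibitor, a higher number a weaker inhibitor. Compound 1 gives 2700 nM and compound 2 gives 8600 nM; of the two, compound 2 has the higher number, and the gap between them lies beyond the scatter, so compound 2 is the weaker inhibitor of the pair on the present data.

Compound 3, `N#CC1CN1C(=O)Nc1ccc(S(N)(=O)=O)cc1`, has not been measured in this assay. It differs from compound 2 in one place: sulfamoyl in place of nitro on an aromatic carbon. Within the data shown here, no step between measured compounds covers this kind of change, so there is nothing from which to read its size or direction. Given that the only comparison available, compound 1 against compound 2 with 8600 nM, concerns a different change, the expectation for compound 3 is kept close to compound 2, with room in both directions. For compound 3 the estimated step from compound 2 is a 1.2-fold lower number from compound 2 to compound 3 (0.09 log units; within the scatter), taken as no more than the scatter. Compound 3 is therefore expected to give 7000 nM, within a range from 2500 nM to 20000 nM.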

Compound 3, half-maximal inhibitory concentration: > 38000 nM
Compound 3: a limit, no number (the forecaster's own chance of this, stated with the estimate: 10%); at least 5.4-fold (0.73 log units) between middle value and limit.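

In this assay compound 3 gives > 38000 nM, which is a limit of the assay and not a number. Sulfamoyl in place of nitro on an aromatic carbon, para to a group of 8 heavy atoms, gives an at least 4.4-fold higher number from compound 2 to compound 3 (0.64 log units; beyond the scatter); this is the only one-place step among the compounds shown, and it establishes that the group at this carbon moves the read-out, with sulfamoyl the weaker of the two groups tried there. The step gives a direction and a minimum size, but its full size stays unknown, and the result rests on a single limit: the limit of > 38000 nM in this assay, at which 1 of the 3 values shown sits.

The compounds shown leave open whether this loss is particular to sulfamoyl or would also come with a methylsulfonyl group or a carboxylic acid on the same aromatic carbon. They also leave open how an amine at that carbon would read, and whether any group there can improve on the nitro of compound 2.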